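A few compounds are considered here, and "the series" means these few. Any claim that something is new, unique, unknown or untested is made for them only; others in the source may bear on it.

In a functional assay on cells (Homo sapiens) for inhibition (on this read-out higher numbers stand for weaker inhibition of growth and lower numbers for stronger inhibition of growth), compound 1 (`C=C/C=C\[C@H](C)[C@H](OC(N)=O)[C@@H](C)[C@H](O)CC/C=C\C(C)[C@@H](O)[C@@H](C)/C=C\CC[C@@H]1O[C@@H](OC)[C@H](C)[C@@H](OCOC)[C@@H]1C`) gives 3.4 nM and compound 2 (`COCOC1=C(C)C(=O)O[C@@H](CC/C=C\[C@H](C)[C@H](O)C(C)/C=C\CC[C@@H](O)[C@H](C)[C@@H](OC(N)=O)C(C)C)[C@H]1C`) gives 46 nM while compound 3 (`CCCCCC[C@H](OC(N)=O)[C@@H](C)[C@H](O)CC/C=C\C(C)[C@@H](O)[C@@H](C)/C=C\CC[C@@H]1O[C@@H](OC)[C@H](C)[C@@H](OCOC)[C@@H]1C`) gives 24 nM and so lies within the scatter of compound 2 but beyond it from compound 1. Among the compounds with values here, compound 4 (`CCCCCC(C)(C)[C@H](OC(N)=O)[C@@H](C)[C@H](O)CC/C=C\C(C)[C@@H](O)[C@@H](C)/C=C\CC[C@@H]1O[C@@H](OC)[C@H](C)[C@@H](OCOC)[C@@H]1C`) brings a group of 8 heavy atoms (8 carbon; no ring) in place of a group of 6 heavy atoms (6 carbon; no ring), on a saturated chain carbon bound to an oxygen next to a carbonyl group and a saturated chain carbon as its only change. Within the data shown here, one measured step bears on this saturated chain carbon: a 7.1-fold higher number from compound 1 to compound 3 (0.85 log units; beyond the scatter) is modest but beyond the scatter, with hexyl entering in place of 1-methylpenta-2,4-dien-1-yl. Among the measured compounds shown here, no measured compound carries the larger group, so that step is only a loose guide. In this assay the step expected is a 1.3-fold higher number from compound 3 to compound 4 (0.10 log units; within the scatter) and thus none beyond the scatter. Compound 4 is estimated at 30 nM with 10 nM to 90 nM as the expected range.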

Compound 4, concentration for 50% growth inhibition: 23 nM
Beside the measured number, compound 4's estimate is 1.3-fold (0.12 log units) above it; low and high end bracket the measured number.
By their numbers in this assay, from the lowest: compound 1; then compounds 4, 3 and 2 (each within the scatter of the next).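

In this assay, within the data shown here, the larger group at this saturated chain carbon gives a 1.0-fold lower number from compound 3 to compound 4 (0.02 log units; within the scatter) and so cannot be told apart from hexyl, which the earlier compounds could not show. Compound 4 also stays clearly apart from the compound with the diene-bearing group, with a 6.8-fold higher number from compound 1 to compound 4 (0.83 log units; beyond the scatter) on the same read-out. No evidence on the cause of this result is available.

On these data alone, what remains open is whether an amine, a carboxylic acid or a shorter chain at this carbon would match hexyl. Also open, as far as these compounds go, is whether any saturated group would reach compound 1.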